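Trimming the isopropyl: compound 3 expected near compound 2

The source may report more compounds than this note shows. Statements on the series, on what has been measured and on what is new or still open speak of the compounds shown alone.

Compound 2 `CC(C)c1ccc([N+](=O)[O-])cc1S(=O)(=O)N(C)/N=C/c1cnn2ccc(C#N)cc12` was measured in an assay on isolated protein for inhibition of phosphatidylinositol 4,5-bisphosphate 3-kinase catalytic subunit beta isoform (Homo sapiens), read by 33P incorporation, with a stated time of 60 min (a higher number here means a weaker inhibitor, a lower number a stronger inhibitor), where compound 2 gives 300 nM. Among the two measured compounds this is the highest number; compound 1 `CN(C)c1ccc([N+](=O)[O-])cc1S(=O)(=O)N(C)/N=C/c1cnn2ccc(C#N)cc12` gives 44 nM, and the step of a 6.8-fold higher number from compound 1 to compound 2 (0.83 log units; beyond the scatter) separates them. Compound 3 `CCc1ccc([N+](=O)[O-])cc1S(=O)(=O)N(C)/N=C/c1cnn2ccc(C#N)cc12` differs from compound 2 by hydrogen in place of methyl on a saturated chain carbon bound to an aromatic carbon and a saturated chain carbon; seen one bond further out, this reads isopropyl to ethyl. Within the data shown here, no measured step shares this change: the only measured step, a 6.8-fold higher number from compound 1 to compound 2 (0.83 log units; beyond the scatter), puts isopropyl in place of dimethylamino on an aromatic carbon, which is a different change and gives no direct guide. With nothing of this kind to go by, compound 3 is expected to land close to compound 2. The step of a 1.2-fold lower number from compound 2 to compound 3 (0.08 log units; within the scatter) is expected to stay within the scatter, in either direction. In this assay compound 3 is estimated at 250 nM, with a range from 90 nM to 700 nM.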

Compound 3, half-maximal inhibitory concentration: 280 nM
Beside the measured number, compound 3's estimate is 1.1-fold (0.05 log units) below it, and the stated range covers the measured number.
By their numbers in this assay, from the lowest: compound 1; then compounds 3 and 2 (each within the scatter of the next).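

In this assay, trimming isopropyl to ethyl gives (a 1.1-fold lower number from compound 2 to compound 3 (0.03 log units; within the scatter)), so for this pair the methyl on the saturated chain carbon makes no readable difference. Ethyl in place of dimethylamino on an aromatic carbon gives (a 6.4-fold higher number from compound 1 to compound 3 (0.80 log units; beyond the scatter)), a step close in size to (a 6.8-fold higher number from compound 1 to compound 2 (0.83 log units; beyond the scatter)), so among these three compounds the two alkyl groups sit together and the dimethylamino of compound 1 stands apart. No evidence at hand accounts for this pattern.

The compounds shown leave open whether the separation belongs to amines more generally, such as methylamino or pyrrolidine, or to dimethylamino alone. They also leave open whether a plain methyl or a longer chain such as propyl would stay with the ethyl and isopropyl pair.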